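Ring Size Change at the Chain Amine

The source may report more compounds than this note shows. Statements on the series, on what has been measured and on what is new or still open speak of the compounds shown alone.

Compound 2, `COc1cc2c(Oc3ccc(NC(=O)c4nn(-c5ccccc5OC(F)(F)F)c(=O)cc4C)cc3F)ccnc2cc1OCCCN1CCCC1`, stands at the lower of the two numbers measured in a functional assay on A549 cells (Homo sapiens) for inhibition, read by MTT assay, with a stated time of 72 h; a higher number here means a weaker inhibitor, a lower number a stronger inhibitor: compound 2 gives 140 nM. Compound 1, `COc1cc2c(Oc3ccc(NC(=O)c4nn(-c5ccccc5C)c(=O)cc4C)cc3F)ccnc2cc1OCCCN1CCCCC1`, differs from compound 2 in several places. In this assay compound 1 gives 1920 nM. Compound 3, `COc1cc2c(Oc3ccc(NC(=O)c4nn(-c5ccccc5OC(F)(F)F)c(=O)cc4C)cc3F)ccnc2cc1OCCCN1CCCCC1`, carries piperidin-1-yl in place of pyrrolidin-1-yl on a saturated chain carbon, three bonds along the chain from an oxygen on an aromatic ring. Going by the values given here, no single-change step between measured compounds covers this swap, so the step of a 1.1-fold higher number from compound 2 to compound 3 (0.06 log units; within the scatter) is expected to be small, not clearly beyond the scatter in either direction. Compound 3 is therefore estimated at 160 nM, with a range from 60 nM to 450 nM.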

Compound 3, half-maximal inhibitory concentration: 120 nM
The estimate for compound 3 lay 1.3-fold (0.12 log units) above the measured number, within the range that was stated.
By their numbers in this assay, from the lowest: compounds 3 and 2 (each within the scatter of the next); then compound 1.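

In this assay, piperidin-1-yl in place of pyrrolidin-1-yl on the chain gives a 1.2-fold lower number from compound 2 to compound 3 (0.07 log units; within the scatter) and stays within the scatter, so this ring size change leaves the number where it was. With piperidin-1-yl held the same, trifluoromethoxy in place of methyl on an aromatic carbon gives a 16-fold lower number from compound 1 to compound 3 (1.20 log units; beyond the scatter) and is a large step beyond the scatter. No measurement here bears on what lies behind either step.

As far as these compounds go, whether a morpholine or a dimethylamino group at the chain end would behave like these two rings remains open. So does what a longer chain, or a methoxy or a chlorine in place of trifluoromethoxy, would do.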